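This account rests on a few compounds, and the source may have more. Where it says the series, first, only, none or still open, it means among the compounds named here.

Measured compounds:
- compound 1, `COc1ccccc1-c1c(C)nn(-c2nc(-c3ccc(Cl)c(Cl)c3)c(SC(C)C)s2)c1C(=O)O`: 14700 nM
- compound 2, `Cc1c(-c2cc(Cl)cc(Cl)c2)c(C(=O)O)nn1-c1nc(-c2ccncc2)c(SC(C)C)s1`: "not active" (no number reported)
- compound 3, `Cc1c(-c2cc(Cl)cc(Cl)c2)c(C(=O)O)nn1-c1nc(-c2ccc3nccn3c2)c(SC(C)C)s1`: "not active" (no number reported)

In a functional assay on BJAB cells (Homo sapiens) for antiproliferative activity, with a stated time of 4 days (a lower number here means that less compound is needed, a higher number that more compound is needed for the effect), compound 1 gives 14700 nM. Among the compounds with values here, it is the only compound of the three for which a number was obtained at all; compound 2 gives "not active" (no number reported) and compound 3 gives "not active" (no number reported), both reported without a number. Compound 1 thus stands as the single measured point of reference, and it is a weak one.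

Compound 4, `Cc1nn(-c2nc(-c3ccc(Cl)c(Cl)c3)c(SC(C)C)s2)c(C(=O)O)c1-c1ccccc1[N+](=O)[O-]`, is the next compound. It differs from compound 1 in one place: nitro in place of methoxy on an aromatic carbon. Everything else in the two structures is the same, so the step from compound 1 to compound 4 rests on this single exchange on the aromatic carbon of the six-membered ring of carbon only.

Within the data shown here, no step between two measured compounds is available to say how much such an exchange shifts the result in this assay. Given that compound 1 already sits far toward the weak end, compound 4 is expected to stay in the same region, with the change most likely within the scatter or, if anything, toward a higher number; the estimated step is a 1.4-fold higher number from compound 1 to compound 4 (0.13 log units; within the scatter). For compound 4 the estimate in this assay is 20000 nM, with a range from 6000 nM to 60000 nM.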

Compound 4, half-maximal effective concentration: 4700 nM
Compound 4: middle estimate off by 4.3-fold (0.63 log units), on the high side; the whole stated range lies above it.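

In this assay, the change from 2-methoxyphenyl to 2-nitrophenyl gives a 3.1-fold lower number from compound 1 to compound 4 (0.50 log units; beyond the scatter), which makes this aromatic carbon, ortho to a large group, the first place in the set where the effect of a single exchange can be read as a number. The step is modest but lies beyond the usual scatter, so the result at this position does respond to the group placed there, and the methoxy of compound 1 can be replaced by nitro without the activity being lost. No measurement at hand accounts for the lower number of compound 4, so the shift stands as an observation about this one pair alone.

Going by these compounds, whether nitro is special at this place remains open, since a single pair cannot show how a nitrile, an amine, a carboxylic acid or a simple chlorine at the same carbon would behave in this assay. Steps to the two compounds reported as not active cannot be read, so they add nothing on how this exchange relates to the other parts of the structure.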